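Trimming the Biaryl to a Phenol: Expected Cytotoxicity

The compounds below may be only part of what the source reports. "The series", "measured", "known", "first", "only" and "open" are said of these compounds alone.

Compound 3 `Cc1ccc(-c2ccc(-n3c(C)ccc3C)cc2C(=O)O)cc1` gives 280000 nM in an ADME assay on MT2 cells (Homo sapiens) for cytotoxicity, read by XTT assay, with a stated time of 4 days (a higher number here means that more compound is tolerated, a lower number that less compound is tolerated), the second highest of the three numbers; compound 2 `Cc1ccc(C)n1-c1ccc(-c2ccccc2)c(C(=O)O)c1` gives 290000 nM and compound 1 `Cc1ccc(C)n1-c1ccc(-c2ccc(CCC(=O)O)cc2)c(C(=O)O)c1` gives 227000 nM, and every gap among the three lies within the scatter, as the steps of a 1.3-fold higher number from compound 1 to compound 2 (0.11 log units; within the scatter), a 1.2-fold higher number from compound 1 to compound 3 (0.09 log units; within the scatter) and a 1.0-fold lower number from compound 2 to compound 3 (0.02 log units; within the scatter) show. Compound 4 `Cc1ccc(C)n1-c1ccc(O)c(C(=O)O)c1` differs from compound 3 by hydroxy in place of 4-methylphenyl on an aromatic carbon. Going by the values given here, no measured step removes this ring; the three known steps only trimmed or added small groups on it and none left the scatter, so for compound 4 in this assay no step beyond the scatter is expected, with the direction left open by the data. Compound 4 is therefore estimated at 300000 nM, between 150000 nM and 600000 nM. The expected step is a 1.1-fold higher number from compound 3 to compound 4 (0.03 log units; within the scatter).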

Compound 4, half-maximal cytotoxic concentration: 334000 nM
Beside the measured number, compound 4's estimate is 1.1-fold (0.05 log units) below it; the range from low to high includes it.
By their numbers in this assay, from the lowest: compounds 1, 3, 2 and 4 (each within the scatter of the next).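

Going by these compounds alone, compound 4 loses the whole aromatic ring at this position, on the carbon ortho to a carboxy group, where the earlier steps only altered groups on that ring. Even so, a 1.2-fold higher number from compound 3 to compound 4 (0.08 log units; within the scatter) and a 1.2-fold higher number from compound 2 to compound 4 (0.06 log units; within the scatter) in this assay show that hydroxy in place of either 4-methylphenyl or phenyl leaves the number within the scatter. Nothing at hand explains this result. As far as these compounds go, whether an amine, a methoxy group or a longer alkyl chain on this carbon would also stay within the scatter remains open.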